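A chloro group added to a compound at the limit

This account rests on a few compounds, and the source may have more. Where it says the series, first, only, none or still open, it means among the compounds named here.

Compound 1 `OCc1cn(Cc2cccc(F)c2)c2ccccc12`: > 31600 nM
Compound 2 `OCc1cn(Cc2cccc(I)c2)c2ccccc12`: > 31600 nM

In an ADME assay on T29 cells (Homo sapiens) for cytotoxicity, read by sulforhodamine B assay, with a stated time of 3 days (on this read-out higher numbers stand for weaker inhibition and lower numbers for stronger inhibition), compound 1 gives > 31600 nM, which is a limit of the assay and not a number. Compound 2 gives > 31600 nM, which is also a limit. The whole record so far is the limit of > 31600 nM in this assay, at which 2 of the 2 values shown sit, so compound 1 has no exact value to start from.

Compound 3 `OCc1cn(Cc2cccc(F)c2)c2ccc(Cl)cc12` keeps the core of compound 1 and makes one change: chloro in place of hydrogen on an aromatic carbon. A chloro group replaces a hydrogen on an aromatic carbon of a six-membered aromatic ring of carbon only, part of a fused or bridged system of two rings.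

Within the data shown here, the only measured step is a step that the two limits leave unreadable from compound 1 to compound 2. Its size cannot be read, so it offers no size to carry over to the new change. Among the measured compounds shown here, with no measured step to suggest a shift, no step beyond the usual scatter is expected in this assay, and compound 3 will most likely be reported as a limit again. The expected step is a number no higher from compound 1 to compound 3 (the limit leaves the size open). For compound 3 the estimated value is 31600 nM, with an expected range from 10000 nM to 100000 nM.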

Compound 3, half-maximal inhibitory concentration: 10000 nM
For compound 3 the middle estimate is 3.2-fold (0.50 log units) above the measured one; the range from low to high includes it.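

In this assay, chloro in place of hydrogen on the six-membered aromatic ring of carbon only gives an at least 3.1-fold lower number from compound 1 to compound 3 (0.49 log units; beyond the scatter), the first readable movement in this small series. The earlier step, iodo in place of fluoro, cannot be read, so this carbon of the shared core is the first place shown where a change moves the number towards stronger inhibition. Compound 3 also gives the series its first exact value, while the other compounds remain at a limit: the limit of > 31600 nM in this assay, at which 2 of the 3 values shown sit.

The full size of the chloro step stays open, since only its minimum can be read, and the compounds shown do not tell whether the shift belongs to chloro itself or would also follow from another group on the same carbon, such as a methoxy group, an amine or a nitrile. They also leave open whether chloro on another carbon of that ring would move the number in the same way, or by a similar amount.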